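A Piperazine Aryl Swap With Only One Step to Lean On

The source may report more compounds than this note shows. Statements on the series, on what has been measured and on what is new or still open speak of the compounds shown alone.

Compound 2 `CCO/N=C(\CCN1CCN(c2ccc(OC)cc2)CC1)c1ccccc1` gives 5% in a functional assay on HEK293 cells with D(4) dopamine receptor (Homo sapiens) as the target, read by FLIPR (on this read-out higher numbers stand for larger maximal responses and lower numbers for smaller maximal responses), and so stands lowest of the two measured compounds. For the measured compounds named here, compound 1 `CCO/N=C(\CCN1CCN(c2ccccc2C#N)CC1)c1ccccc1` gives 82% in this assay, and the only measured step is a number 77 percentage points lower from compound 1 to compound 2 (beyond the scatter), a change of 4-methoxyphenyl in place of 2-cyanophenyl on an amine nitrogen in a ring. Compound 3 `CCO/N=C(\CCN1CCN(c2cccc(OCC)c2)CC1)c1ccccc1` is not yet measured. It differs from compound 2 as follows: 3-ethoxyphenyl in place of 4-methoxyphenyl on an amine nitrogen in a ring. Going by the values given here, no measured step tests this kind of change: the one step recorded swaps out 2-cyanophenyl, not a methoxy for an ethoxy group with a different ring position. On these data alone, compound 2 sits close to the floor, so a large fall is hardly possible, while a gain of any size remains open. Compound 3 is therefore estimated at 20% in this assay, with a range from 0% to 55%. This means a step of a number 15 percentage points higher from compound 2 to compound 3 (beyond the scatter) is expected, a modest rise that is uncertain in size.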

Compound 3, largest response reached (reported as efficacy), in percent of the reference or control that the assay uses: 84%
Compound 3: middle estimate off by 64 percentage points, on the low side; measured number outside the range, above it.
By their numbers in this assay, from the lowest: compound 2; then compounds 1 and 3 (each within the scatter of the next).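

The step of a number 79 percentage points higher from compound 2 to compound 3 (beyond the scatter) in this assay shows that a low maximal response does not follow from having an oxygen-linked group on the phenyl ring at this amine nitrogen, since 3-ethoxyphenyl and 4-methoxyphenyl have the same counts of donors and acceptors yet sit far apart. The swap of 2-cyanophenyl for 3-ethoxyphenyl gives a number 2 percentage points higher from compound 1 to compound 3 (within the scatter), so these two groups cannot be told apart on this read-out, and compound 2 alone stands low among the three. Nothing measured here explains why the response changes so sharply.

The step from compound 2 to compound 3 changes both the chain and its place on the phenyl ring, so the compounds shown do not separate the two. A 3-methoxyphenyl or a 4-ethoxyphenyl group would be needed to tell which of them carries the difference.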